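The source may hold more compounds than are shown below. What is called first, only, known or untested is meant among the compounds shown, and "the series" means these compounds.

Compound 3 `CN(C)CCCOc1ccc(CN2CC[C@H](NC(=O)c3ccncc3)C2)cc1` carries a pyridin-4-yl on a carbonyl carbon whose other neighbour is an amide-type nitrogen. In an assay on HEK293 cells for binding affinity to Urotensin-2 receptor (Homo sapiens), read by radioligand binding (on this read-out higher numbers stand for weaker inhibition and lower numbers for stronger inhibition), compound 3 gives < 10000 nM, which is a limit of the assay and not a number. In this assay compound 1 `Cc1ccc(C(=O)N[C@H]2CCN(Cc3ccc(OCCCN(C)C)cc3)C2)cc1C` gives < 10000 nM, likewise a limit. In this assay compound 2 `CN(C)CCCOc1ccc(CN2CC[C@H](NC(=O)c3ccc(C(F)(F)F)cc3)C2)cc1` gives < 10000 nM, again a limit. The steps a step that the two limits leave unreadable from compound 1 to compound 2, a step that the two limits leave unreadable from compound 1 to compound 3 and a step that the two limits leave unreadable from compound 2 to compound 3 cannot be sized because of the limit of < 10000 nM in this assay, at which 3 of the 3 values shown sit. Compound 4 `CN(C)CCCOc1ccc(CN2CC[C@H](NC(=O)c3cc4ccccc4o3)C2)cc1` differs from compound 3 in one place: 1-benzofuran-2-yl in place of pyridin-4-yl on a carbonyl carbon. With no readable step to lean on, the size and direction of a step that the limit leaves unreadable from compound 3 to compound 4 can only be expected loosely. Compound 4 is expected to give about 1000 nM in this assay, estimated to fall between 100 nM and 8000 nM.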

Compound 4, inhibition constant: 2510 nM
Estimate against measurement, compound 4: 2.5-fold (0.40 log units) below; low and high end bracket the measured number.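

Among the compounds shown here, no step to compound 4 from compound 1, compound 2 or compound 3 can be sized, because each of those three compounds gives only a limit: the limit of < 10000 nM in this assay, at which 3 of the 4 values shown sit. The compounds shown leave open how far the 1-benzofuran-2-yl of compound 4 separates it from the other three.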